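From Furan-2-yl to Pyridin-2-yl at the Inactive Limit

A few compounds are considered here, and "the series" means these few. Any claim that something is new, unique, unknown or untested is made for them only; others in the source may bear on it.

Compound 2 `O=C(N/N=C/c1ccco1)c1cccc(S(=O)(=O)N2CCOCC2)c1` stands at the edge of a functional assay on PC-3 cells (Homo sapiens) for antiproliferative activity, read by MTT assay, with a stated time of 72 h (on this read-out lower numbers stand for stronger inhibition and higher numbers for weaker inhibition), where it gives > 100000 nM, a limit of the measurement rather than a number. Compound 1 `C/C(=N\NC(=O)c1cccc(S(=O)(=O)N2CCOCC2)c1)c1cccc(O)c1` likewise reaches only a limit, > 100000 nM. Both results rest at the limit of > 100000 nM in this assay, at which 2 of the 2 values shown sit. Compound 3 `O=C(N/N=C/c1ccccn1)c1cccc(S(=O)(=O)N2CCOCC2)c1` differs from compound 2 by pyridin-2-yl in place of furan-2-yl on a carbon with a double bond to nitrogen. Among the measured compounds shown here, no measured step sets the size of such a change, so the expected shift a number no higher from compound 2 to compound 3 (the limit leaves the size open) is none beyond the scatter. Compound 3 is therefore estimated at 100000 nM, within 30000 nM to 300000 nM, most likely again reported only as a limit.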

Compound 3, half-maximal inhibitory concentration: 88100 nM
Estimate against measurement, compound 3: 1.1-fold (0.06 log units) above, within the range that was stated.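

In this assay, among the compounds shown here, compound 3 gives 88100 nM, the only value here that is a number rather than a limit, so pyridin-2-yl on this carbon with a double bond to nitrogen gives a first reading of the series. The change from furan-2-yl gives an at least 1.1-fold lower number from compound 2 to compound 3 (0.05 log units; that floor lies within the scatter), a floor that does not separate the two groups. Most values shown still rest at the limit: the limit of > 100000 nM in this assay, at which 2 of the 3 values shown sit.

As far as these compounds go, how far the true step exceeds that floor stays open. So does whether phenyl or a carboxylic acid at this place would give a clearly lower number.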